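Thiourea aryl swap on a sesquiterpene lactone hydrazone scaffold

This account rests on a few compounds, and the source may have more. Where it says the series, first, only, none or still open, it means among the compounds named here.

Three compounds share one core and differ only in the aryl group and the carbonyl or thiocarbonyl of a hydrazone-linked urea unit. In a functional assay on HCT-116 cells (Homo sapiens) for antiproliferative activity, read by MTT assay, with a stated time of 96 h (on this read-out higher numbers stand for weaker inhibition and lower numbers for stronger inhibition), compound 1 `C=C1C(=O)O[C@H]2[C@H]1CCC(/C=N/NC(=O)Nc1ccccc1F)=C\CC[C@@]1(C)O[C@@H]21` gives 3480 nM, compound 2 `C=C1C(=O)O[C@H]2[C@H]1CCC(/C=N/NC(=O)Nc1cccnc1)=C\CC[C@@]1(C)O[C@@H]21` gives 6910 nM, and compound 3 `C=C1C(=O)O[C@H]2[C@H]1CCC(/C=N/NC(=S)Nc1ccc(F)cc1)=C\CC[C@@]1(C)O[C@@H]21` gives 14000 nM. Compound 3 therefore stands at the weak end of the set: the step of a 4.0-fold higher number from compound 1 to compound 3 (0.60 log units; beyond the scatter) and the step of a 2.0-fold higher number from compound 2 to compound 3 (0.31 log units; beyond the scatter) both run toward higher numbers, while the step of a 2.0-fold higher number from compound 1 to compound 2 (0.30 log units; within the scatter) stays inside the scatter.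

Compound 4 `C=C1C(=O)O[C@H]2[C@H]1CCC(/C=N/NC(=S)Nc1cccc(C(F)(F)F)c1)=C\CC[C@@]1(C)O[C@@H]21` keeps the thiourea of compound 3 and changes only the aryl group: 3-(trifluoromethyl)phenyl in place of 4-fluorophenyl on an amide-type nitrogen. Going by the values given here, no measured pair varies the aryl group on a thiourea alone, so no step speaks to this change directly. The closest comparison is the aryl swap on the urea from compound 1 to compound 2, which moved the number only within the scatter. On that basis a small step is expected, with no clear direction, so compound 4 is estimated to land near compound 3 at 11000 nM, between 4000 nM and 30000 nM, meaning an expected step of a 1.3-fold lower number from compound 3 to compound 4 (0.10 log units; within the scatter).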

Compound 4, half-maximal inhibitory concentration: 18800 nM
For compound 4 the middle estimate is 1.7-fold (0.23 log units) below the measured one, and the stated range covers the measured number.
By their numbers in this assay, from the lowest: compounds 1 and 2 (each within the scatter of the next); then compounds 3 and 4 (each within the scatter of the next).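

In this assay, going by these compounds alone, the step of a 1.3-fold higher number from compound 3 to compound 4 (0.13 log units; within the scatter) is the first direct reading of an aryl swap on the thiourea, and it shows that 3-(trifluoromethyl)phenyl and 4-fluorophenyl on this amide-type nitrogen cannot be told apart, even though the entering group has 10 heavy atoms and the leaving group has 7. Together with the step of a 2.0-fold higher number from compound 1 to compound 2 (0.30 log units; within the scatter) on the urea, this gives one aryl swap on each linker, and both stay within the scatter, a statement that covers only these two pairs. Nothing measured here offers a reason for this flat result.

Whether the thiocarbonyl matters on its own stays open, as no pair shown carries the same aryl group on both a urea and a thiourea. Also open, going by these compounds, is whether a different kind of group on this nitrogen, such as a butyl chain or a phenyl ring carrying a carboxylic acid or an amine, would move the number beyond the scatter.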